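Changing the aryl on the piperazine nitrogen: compound 3 to 4

The compounds below may be only part of what the source reports. "The series", "measured", "known", "first", "only" and "open" are said of these compounds alone.

Compound 1 `Nc1scc(CN2CCN(c3ccc(Cl)cc3Cl)CC2)c1C(=O)c1ccc(Cl)cc1` gives 2% in a functional assay on CHO cells with adenosine receptor A1 (Homo sapiens) as the target, read by cAMP accumulation and immunoassay, with a stated time of 6 min, tested at 0.01 uM; a higher number here means a weaker effect of the compound at the concentration tested, a lower number a stronger effect.
Compound 2 `Nc1scc(CN2CCN(c3ccc(C(F)(F)F)cc3)CC2)c1C(=O)c1cccc(C(F)(F)F)c1` gives -12% in this assay.
Compound 3 `Nc1scc(CN2CCN(c3cccc(F)c3)CC2)c1C(=O)c1cccc(C(F)(F)F)c1` gives -11% in this assay.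

Compound 3 sits second highest of the three numbers. Its nearest neighbour is compound 2, within the scatter; compound 1 lies beyond the scatter above it. Compound 4 `Nc1scc(CN2CCN(c3c(F)cccc3F)CC2)c1C(=O)c1cccc(C(F)(F)F)c1` differs from compound 3 in one place: 2,6-difluorophenyl in place of 3-fluorophenyl on an amine nitrogen in a ring. Among the measured compounds shown here, one measured step bears on this, since it also exchanges the group on the same ring nitrogen: a number 1 percentage points higher from compound 2 to compound 3 (within the scatter). Because that step a number 1 percentage points higher from compound 2 to compound 3 (within the scatter) stayed within the scatter, a step from compound 3 to compound 4 is expected to stay within it as well, with no clear direction, a number 3 percentage points higher from compound 3 to compound 4 (within the scatter). Compound 4 is therefore estimated at -8%, between -25% and 10%.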

Compound 4, a percentage reported as activity, at one concentration (the size of the read-out at that concentration, not a potency): 2.1%
Estimate against measurement, compound 4: 10.1 percentage points below; the measured number falls inside the stated range.
By their numbers in this assay, from the lowest: compounds 2 and 3 (each within the scatter of the next); then compounds 1 and 4 (each within the scatter of the next).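

In this assay, among the compounds shown here, the 2,6-difluorophenyl group gives the first steps beyond the scatter at this amine nitrogen in a ring, with a number 13.1 percentage points higher from compound 3 to compound 4 (beyond the scatter) and a number 14.1 percentage points higher from compound 2 to compound 4 (beyond the scatter) on the shared core. The aryl group at this position can therefore shift the read-out towards a weaker effect, which the earlier exchange, with a number 1 percentage points higher from compound 2 to compound 3 (within the scatter) and no more, did not show. Nothing measured here accounts for this shift.

The compounds shown leave open how a pyridine ring or an unsubstituted phenyl on this nitrogen would read. They also leave open whether the shift would recur with a different group on the other aryl ketone.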